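The compounds below may be only part of what the source reports. "The series", "measured", "known", "first", "only" and "open" are said of these compounds alone.

Compound 1 `C[Se]/C(=N\C(=O)c1cccs1)NC(=O)c1cccs1` and compound 2 `CS/C(=N\C(=O)c1cccs1)NC(=O)c1cccs1` share one core, and compound 3 `C[Se]/C(=N\C(=O)c1cnc2ccccc2c1)NC(=O)c1cnc2ccccc2c1` and compound 4 `CS/C(=N\C(=O)c1cnc2ccccc2c1)NC(=O)c1cnc2ccccc2c1` share another. In a functional assay on K562 cells (Homo sapiens) for cytotoxicity, read by MTT assay, with a stated time of 72 h (a higher number here means a weaker inhibitor of growth, a lower number a stronger inhibitor of growth), compound 1 gives 6070 nM, while compound 2 gives 72600 nM. The change between them, (a group of 2 heavy atoms (1 carbon, 1 sulfur; no ring) in place of a group of 2 heavy atoms (1 carbon, 1 selenium; no ring), on a carbon with a double bond to nitrogen), produced a 12-fold higher number from compound 1 to compound 2 (1.08 log units; beyond the scatter). Compound 3 gives 3800 nM in this assay; its two values with compound 1 are within the scatter, and compound 3 lies well apart from compound 2. The difference between the core of compound 1 and the core of compound 3 is not broken down here. Compound 4 is not yet measured in this assay. It differs from compound 3 by a group of 2 heavy atoms (1 carbon, 1 sulfur; no ring) in place of a group of 2 heavy atoms (1 carbon, 1 selenium; no ring), on a carbon with a double bond to nitrogen, the same change that was made from compound 1 to compound 2. Among the measured compounds shown here, the step from compound 3 to compound 4 is estimated at a 7.9-fold higher number from compound 3 to compound 4 (0.90 log units; beyond the scatter), beside the earlier one, because the single example, a 12-fold higher number from compound 1 to compound 2 (1.08 log units; beyond the scatter), was large and beyond the scatter, although with only one example the size is uncertain. Compound 4 is therefore expected to give about 30000 nM, estimated between 12000 nM and 90000 nM.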

Compound 4, concentration for 50% growth inhibition: 65800 nM
Beside the measured number, compound 4's estimate is 2.2-fold (0.34 log units) below it; low and high end bracket the measured number.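

In this assay, methylsulfanyl in place of the group of carbon and selenium gave a 17-fold higher number from compound 3 to compound 4 (1.24 log units; beyond the scatter), and this step matches the earlier one on the other core: the same change on two cores in this assay, a 12-fold higher number (1.08 log units; beyond the scatter) from compound 1 to compound 2 and a 17-fold higher number (1.24 log units; beyond the scatter) from compound 3 to compound 4, 1.4-fold (0.16 log units) apart, within the scatter of two such steps. Within these two pairs, the change therefore carries over from one core to the other in both direction and size, with compound 1 and compound 3, the selenium members, giving the lower number in each pair. Among the compounds shown here, this rests on only two cores in a single assay, so it does not show that the step would hold on other cores, and it does not explain why the exchange has this size.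

The compounds shown leave open how the numbers would respond if a longer chain, such as ethyl or benzyl, took the place of the methyl on selenium or sulfur, or if methoxy stood in the same place. They also leave open whether the step would persist with an amine or a carboxylic acid added to the core, or in any other cell line.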